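Inverting the single stereocentre of compound 3

The compounds below may be only part of what the source reports. "The series", "measured", "known", "first", "only" and "open" are said of these compounds alone.

For the measured compounds named here, compound 1 `CN1CCN(c2ccc(Nc3ncc4nc(Nc5ccccc5)n([C@@H]5CCNC5)c4n3)cc2)CC1`, compound 2 `CN1CCN(c2ccc(Nc3ncc4nc(Nc5ccccc5)n([C@H]5CCN(S(C)(=O)=O)C5)c4n3)cc2)CC1` and compound 3 `CN1CCN(c2ccc(Nc3ncc4nc(Nc5ccccc5)n([C@@H]5CCN(S(=O)(=O)C6CC6)C5)c4n3)cc2)CC1` make up the measured part of the series so far. In a functional assay on A549 cells (Homo sapiens) for antiproliferative activity, read by MTT assay, with a stated time of 72 h (a lower number here means a stronger inhibitor, a higher number a weaker inhibitor), compound 1 has the entry "not determined" (no result reported). Compound 2 has the entry "not determined" (no result reported). Going by the values given here, compound 3 gives 2910 nM, the only number available, so its standing relative to the other two compounds cannot be judged.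

Compound 4 `CN1CCN(c2ccc(Nc3ncc4nc(Nc5ccccc5)n([C@H]5CCN(S(=O)(=O)C6CC6)C5)c4n3)cc2)CC1` is the next case, and it differs from compound 3 as follows: the two compounds have the same atoms and bonds and differ only in configuration as drawn: 1 of 1 stereo elements differ; a stereocentre at a saturated ring carbon is drawn R in compound 3 and S in compound 4. Nothing leaves and nothing enters.

Among the compounds with values here, no pair of measured compounds shows what such a change does in this assay, so no direction is favoured and no step beyond the scatter is expected. Within the data shown here, the only anchor is compound 3 at 2910 nM, and the range is kept wide because that single value is all there is to go on. The expected change is a 1.0-fold lower number from compound 3 to compound 4 (0.00 log units; within the scatter). For compound 4 the estimated value is 2900 nM, with an expected range of 900 nM to 9000 nM.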

Compound 4, half-maximal inhibitory concentration: 540 nM
For compound 4 the middle estimate is 5.4-fold (0.73 log units) above the measured one, and the stated range ends above it.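

Going from R to S as drawn at this saturated ring carbon gives a 5.4-fold lower number from compound 3 to compound 4 (0.73 log units; beyond the scatter), so in this assay the outcome depends on configuration at this position, something a single number could not show. The step belongs to the stereocentre alone because of one structural fact: the fact that compounds 3 and 4 differ only in the configuration as drawn. Among the compounds with numbers, S as drawn therefore gives the lower value, but this rests on one pair carrying the cyclopropyl sulfonyl group.

Going by these compounds, whether the same direction and a similar size of step hold with a longer alkyl chain on the sulfonyl group, or with an amide in place of the sulfonamide, remains open. Also open, on these data alone, is whether the difference between the two forms carries over to other cell lines.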